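This account rests on a few compounds, and the source may have more. Where it says the series, first, only, none or still open, it means among the compounds named here.

Compound 1 `COc1ccc(CS(=O)(=O)/C=C/c2ccccc2OC)cc1N`: 7500 nM
Compound 2 `COC(=O)[C@H](C)Nc1cc(CS(=O)(=O)/C=C/c2c(OC)cc(OC)cc2OC)ccc1OC`: 200 nM

Both values come from a functional assay on K562 cells (Homo sapiens) for cytotoxicity, read by trypan blue exclusion, with a stated time of 96 h; on this read-out lower numbers stand for stronger inhibition and higher numbers for weaker inhibition. Compound 2 has the lower of the two numbers, and its gap to compound 1 lies well beyond the usual scatter. The two compounds differ in more than one place, however, so that gap cannot be credited to any single group.

Compound 3 `COc1cc(OC)c(/C=C/S(=O)(=O)Cc2ccc(OC)c(NCCC(=O)O)c2)c(OC)c1` has 2-carboxyethyl in place of 1-(methoxycarbonyl)ethyl on a nitrogen on an aromatic ring. Going by the values given here, no measured pair shows a change of this kind, so the expectation is uncertain. The starting point is compound 2 at 200 nM, and a modest move towards weaker inhibition in this assay is expected, possibly not much beyond the scatter. The expected change is a 2.0-fold higher number from compound 2 to compound 3 (0.30 log units; within the scatter). For compound 3 the estimated value is 400 nM, with an expected range of 80 nM to 2500 nM.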

Compound 3, half-maximal inhibitory concentration: 5000 nM
Compound 3: the middle estimate sits 13-fold (1.10 log units) below what was measured, outside the stated range (above it).
By their numbers in this assay, from the lowest: compound 2; then compounds 3 and 1 (each within the scatter of the next).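

In this assay the group on this nitrogen turns out to matter a great deal: putting 2-carboxyethyl in place of 1-(methoxycarbonyl)ethyl gives a 25-fold higher number from compound 2 to compound 3 (1.40 log units; beyond the scatter) and so a clear loss of inhibition. This is the only pair shown that differs in one place, so here, unlike in the earlier comparison, the gap can be tied to a single group. Nothing available explains why this swap has so large an effect.

The swap still changes several things at once: a methyl ester becomes a carboxylic acid, the defined stereocentre disappears, and the chain is joined to the nitrogen differently. A carboxylic acid on a 1-carboxyethyl group, or a methyl ester on the 2-carboxyethyl chain, would separate these changes, while an amide or a longer chain on the same nitrogen remains an open question.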